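Aryl urea series: thermal shift notes toward compound 4

This account rests on a few compounds, and the source may have more. Where it says the series, first, only, none or still open, it means among the compounds named here.

Measured compounds:
compound 1 `Cc1ccccc1NC(=O)Nc1cc(C(C)(C)C)nn1-c1ccccc1`: 7.1 degrees C
compound 2 `CC(C)(C)c1cc(NC(=O)Nc2ccc(F)cc2)n(-c2ccccc2)n1`: 7.4 degrees C
compound 3 `Cc1ccc(S(=O)(=O)NC(=O)Nc2cc(C(C)(C)C)nn2-c2ccccc2)cc1`: -0.3 degrees C

In an assay on isolated protein for inhibition of STE20-like serine/threonine-protein kinase (Homo sapiens), read by thermal shift assay, tested at 10 uM (a lower number here means that the compound stabilises the target less, a higher number that the compound stabilises the target more against heat), compound 2 gives 7.4 degrees C, the highest of the three numbers. Its gap to compound 1, a number 0.30 degrees C higher from compound 1 to compound 2 (within the scatter), lies within the scatter, so compound 1 and compound 2 cannot be ordered. Among the measured compounds shown here, compound 3, carrying a sulfonyl group on the amide-type nitrogen rather than an aryl group, gives -0.3 degrees C; no single-point step to compound 2 is counted, but the two values show a large gap.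

Compound 4 `COc1cccc(NC(=O)Nc2cc(C(C)(C)C)nn2-c2ccccc2)c1` is not yet measured. Relative to compound 2 the change is 3-methoxyphenyl in place of 4-fluorophenyl on an amide-type nitrogen. For the measured compounds named here, the one measured step that bears on it is the swap of one aryl group for another on the same amide-type nitrogen, from compound 1 to compound 2, which gave a number 0.30 degrees C higher from compound 1 to compound 2 (within the scatter), within the scatter. On that basis a second aryl-for-aryl exchange at this position is expected to produce no step beyond the scatter in this assay, in either direction.

The expected step is a number 0.40 degrees C lower from compound 2 to compound 4 (within the scatter). Compound 4 is therefore estimated at 7 degrees C, with a range from 5.5 degrees C to 8.5 degrees C.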

Compound 4, shift of the target's melting temperature: 3.6 degrees C
Estimate against measurement, compound 4: 3.4 degrees C above, and the stated range ends above it.
By their numbers in this assay, from the lowest: compound 3; then compound 4; then compounds 1 and 2 (each within the scatter of the next).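

The aryl group on the amide-type nitrogen is not a neutral position in this assay: 3-methoxyphenyl in place of 4-fluorophenyl gives a number 3.8 degrees C lower from compound 2 to compound 4 (beyond the scatter) and 3-methoxyphenyl in place of 2-methylphenyl gives a number 3.5 degrees C lower from compound 1 to compound 4 (beyond the scatter). Both steps lie beyond the scatter, whereas the earlier aryl-for-aryl exchange gave only a number 0.30 degrees C higher from compound 1 to compound 2 (within the scatter), so one such exchange at this position can leave the number unchanged within the scatter while another moves it clearly, and the two earlier aryl compounds alone gave no sign of this. No measurement at hand accounts for the drop.

The three aryl groups differ both in the group they carry and in where it sits on the ring, so the compounds shown cannot separate these two changes, and the drop cannot be tied to the methoxy group as such. Also open, on these data alone, is how a phenyl ring carrying a hydroxyl group, an amine or a carboxylic acid in place of the methoxy group would read in this assay.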